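Pyridin-2-yl replaces chloromethyl at the assay limit

The source may hold more compounds than are shown below. What is called first, only, known or untested is meant among the compounds shown, and "the series" means these compounds.

Measured in an ADME assay on H9c2 cells (Rattus norvegicus) for cytotoxicity, read by resazurin assay, with a stated time of 72 h (a lower number here means that less compound is tolerated, a higher number that more compound is tolerated), as the half-maximal cytotoxic concentration:
- compound 1 `C/C(=N\Nc1nc(CCl)cs1)c1ccc(Cl)c(Cl)c1` gives > 50000 nM (a limit)
- compound 2 `C/C(=N\N=c1\scc(-c2ccccc2)n1C)c1ccc(Cl)c(Cl)c1` gives > 50000 nM (a limit)
- compound 3 `C/C(=N\Nc1nc(-c2ccccc2)c(C)s1)c1ccc(Cl)c(Cl)c1` gives > 50000 nM (a limit)

None of these three entries is an exact number, so no order among the compounds can be read from them. Compound 1 stands at the limit of > 50000 nM in this assay, at which 3 of the 3 values shown sit, and so has no exact value of its own. Compound 4 `C/C(=N\Nc1nc(-c2ccccn2)cs1)c1ccc(Cl)c(Cl)c1` is not yet measured and carries pyridin-2-yl in place of chloromethyl on an aromatic carbon with the rest of compound 1 kept. For the measured compounds named here, no measured step shows what such a change does. The expectation rests on compound 1 and its > 50000 nM limit alone. The expected step of an at least 1.4-fold lower number from compound 1 to compound 4 (0.15 log units; that floor lies within the scatter) in this assay is small and leans toward less compound being tolerated. Compound 4 is estimated at 35000 nM with an expected range from 10000 nM to 50000 nM in this assay.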

Compound 4, half-maximal cytotoxic concentration: 10200 nM
Compound 4: middle estimate off by 3.4-fold (0.54 log units), on the high side; low and high end bracket the measured number.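

In this assay, pyridin-2-yl in place of chloromethyl, on the aromatic carbon next to the ring nitrogen, gives an at least 4.9-fold lower number from compound 1 to compound 4 (0.69 log units; beyond the scatter). This shows that a change at this position can lower the amount of compound the cells tolerate. Compound 4 alone has an exact number rather than a limit: the limit of > 50000 nM in this assay, at which 3 of the 4 values shown sit.

From the compounds shown here alone, compound 1 has only a limit, so the full size of this step stays unknown. Also open, going by these compounds, is what a simple amine or a carboxylic acid at this position would do.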